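The source may hold more compounds than are shown below. What is called first, only, known or untested is meant among the compounds shown, and "the series" means these compounds.

Measured so far:
compound 1 `Oc1cccc(-c2ccc3c(-c4cncnc4)c(O)ccc3c2)c1` — 41%
compound 2 `Oc1ccccc1-c1ccc2c(-c3cncnc3)cccc2c1` — < 10%

In an assay for binding affinity to 17-beta-hydroxysteroid dehydrogenase type 1 (Homo sapiens), read by scintillation counting, with a stated time of 10 min, tested at 1 uM (on this read-out lower numbers stand for less inhibition and higher numbers for more inhibition at the one concentration tested (going by the name of the read-out)), compound 1 gives 41%. Compound 2 is known only by a limit in this assay, < 10% (the limit of < 10% in this assay, at which 1 of the 2 values shown sits). Compound 3 `Oc1cccc(-c2ccc3c(-c4cncnc4)cccc3c2)c1` is not yet measured; it differs from compound 2 by 3-hydroxyphenyl in place of 2-hydroxyphenyl on an aromatic carbon. Compound 1 carries the same 3-hydroxyphenyl and gives 41%. Hence the expected step is a number at least 15 percentage points higher from compound 2 to compound 3 (beyond the scatter), upward and beyond the scatter. For compound 3 the estimate in this assay is 25%, from 5% to 50%.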

Compound 3, a percentage reported as inhibition, at one concentration (the size of the read-out at that concentration, not a potency): < 10%
Compound 3: no number, only a limit; the forecaster's own chance of this, stated with the estimate: 25%; middle value at least 15 percentage points from the limit.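

In this assay, among these compounds, hydrogen in place of hydroxy on an aromatic carbon of the core gives a number at least 31 percentage points lower from compound 1 to compound 3 (beyond the scatter), so this hydroxy is the one change here with a readable effect. Compound 3 is known only by a limit, < 10%, so 3-hydroxyphenyl without the core hydroxy gives no readable number. The change from 2-hydroxyphenyl to 3-hydroxyphenyl cannot be read, since both values are limits: the limit of < 10% in this assay, at which 2 of the 3 values shown sit.

On these data alone, whether an amine or a methoxy group in place of the core hydroxy would keep the read-out stays open. Also open, as far as these compounds go, is how 2-hydroxyphenyl behaves with the core hydroxy present.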